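Diethylamino to 1H-1,2,4-triazol-1-yl: expectations for compound 4

A few compounds are considered here, and "the series" means these few. Any claim that something is new, unique, unknown or untested is made for them only; others in the source may bear on it.

Among the measured compounds shown here, in an ADME assay on CHO cells (Cricetulus griseus) for cytotoxicity, read by MTT assay (a higher number here means a weaker inhibitor, a lower number a stronger inhibitor), compound 3 `CCN(CC)CC(CN(CC)CC)NCc1ccc(OC)cc1` gives 170000 nM, the only exact number so far. For compound 1 `CCN(CC)CC(Cn1cc(C)c(=O)[nH]c1=O)NCc1ccc(OC)cc1`, the entry reads "not determined" (no result reported). Compound 4 `CCN(CC)CC(Cn1cncn1)NCc1ccc(OC)cc1` differs from compound 3 by 1H-1,2,4-triazol-1-yl in place of diethylamino on a saturated chain carbon, two bonds along the chain from an amine nitrogen. For the measured compounds named here, no measured pair isolates this change. The nearest guide is compound 2 `CCN(CC)CC(Cn1cncn1)NCc1ccc(Cl)cc1`, which also carries 1H-1,2,4-triazol-1-yl and gives > 300000 nM, a limit of the assay. The expected step, a 1.5-fold higher number from compound 3 to compound 4 (0.18 log units; within the scatter), is small, toward weaker inhibition and about the size of the scatter. For compound 4 the estimated value is 260000 nM, with an expected range of 120000 nM to 500000 nM.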

Compound 4, half-maximal inhibitory concentration: 159000 nM
Estimate against measurement, compound 4: 1.6-fold (0.21 log units) above; the measured number falls inside the stated range.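

In this assay, the pair at this position gives a 1.1-fold lower number from compound 3 to compound 4 (0.03 log units; within the scatter): on a saturated chain carbon, two bonds along the chain from an amine nitrogen, 1H-1,2,4-triazol-1-yl and diethylamino cannot be told apart. Methoxy in place of chloro on an aromatic carbon gives an at least 1.8-fold lower number from compound 2 to compound 4 (0.27 log units; that floor lies within the scatter). That step is only a floor, as the entry for compound 2 is a limit and not a number: the limit of > 300000 nM in this assay, at which 1 of the 4 values shown sits.

From the compounds shown here alone, whether methoxy and chloro truly differ in this assay stays open. So does whether a carboxylic acid or a longer chain at the triazolyl position would depart from these values.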